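Amide swap at the carbonyl: from compound 2 to compound 4

The source may report more compounds than this note shows. Statements on the series, on what has been measured and on what is new or still open speak of the compounds shown alone.

Compound 1, `COc1ccc2nc(NC(=O)c3ccc(F)cc3)n(C)c2c1`: in a toxicity assay on THP-1 cells (Homo sapiens) for inhibition (on this read-out lower numbers stand for higher toxicity in this test and higher numbers for lower toxicity in this test), compound 1 gives > 100000 nM, which is a limit of the assay and not a number.
Compound 2, `COc1ccc(-c2cnc(NC(=O)c3ccccc3OC)n2C)cc1`: in this assay compound 2 gives > 100000 nM, again a limit and not a number.
Compound 3, `Cn1c(-c2ccc(Cl)cc2)cnc1NC(=O)c1ccc(F)cc1`: in this assay compound 3 gives 37000 nM.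

Compound 2 thus stands at the limit of > 100000 nM in this assay, at which 2 of the 3 values shown sit, and compound 1 sits there with it, while compound 3 alone returns a number. Among the measured compounds shown here, no step between two measured compounds is available, so there is no measured guide for what a change at the carbonyl carbon does.

Compound 4, `COc1ccc(-c2cnc(NC(=O)c3cccc(F)c3)n2C)cc1`, differs from compound 2 in one place: 3-fluorophenyl in place of 2-methoxyphenyl on a carbonyl carbon. Compound 3 also carries a fluorophenyl on its carbonyl carbon and gives a number, so a step from the limit toward a measurable value cannot be excluded, yet the account rests on three compounds only. The expected step of an at least 1.1-fold lower number from compound 2 to compound 4 (0.04 log units; that floor lies within the scatter) is therefore small or none beyond the scatter. Compound 4 is estimated at 90000 nM, with a range from 30000 nM to 250000 nM, and it may well again return only a limit.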

Compound 4, half-maximal cytotoxic concentration: > 100000 nM
Compound 4 gave a limit, no number (the forecaster's own chance of this, stated with the estimate: 55%); at least 1.1-fold (0.04 log units) between middle value and limit.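

Compound 2 and compound 4 both return only a limit and not a number, so no step can be read between them: the limit of > 100000 nM in this assay, at which 3 of the 4 values shown sit. The compounds shown leave open whether 3-fluorophenyl in place of 2-methoxyphenyl on a carbonyl carbon changes the result in this assay at all.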